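Thiosemicarbazide amides: a fluorine for a chlorine

The source may hold more compounds than are shown below. What is called first, only, known or untested is meant among the compounds shown, and "the series" means these compounds.

Compound 1 `O=C(NC(=S)NNc1ncnc2ccccc12)c1ccccc1F`: 4610 nM
Compound 2 `COc1cc2ncnc(NNC(=S)NC(=O)c3ccccc3Cl)c2cc1OC`: 9670 nM
Compound 3 `COc1cc2ncnc(NNC(=S)NC(=O)c3ccc(Cl)cc3)c2cc1OC`: 7530 nM

Of the compounds shown here, three have been measured in a functional assay on CNE-2 cells (Homo sapiens) for cytotoxicity, read by MTT assay, with a stated time of 72 h; on this read-out higher numbers stand for weaker inhibition and lower numbers for stronger inhibition. Compound 3 stands second highest of the three numbers; its nearest neighbour is compound 2, and these two lie within the scatter of each other, as do compound 3 and compound 1. Among the compounds with values here, no compound can be called the strongest or the weakest on these data.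

The unmeasured compound 4 `COc1cc2ncnc(NNC(=S)NC(=O)c3ccccc3F)c2cc1OC` shares its core with compound 3 and differs in one place: 2-fluorophenyl in place of 4-chlorophenyl on a carbonyl carbon. Within the data shown here, the one measured step that bears on this is a 1.3-fold lower number from compound 2 to compound 3 (0.11 log units; within the scatter), which moved the chlorine from one position on the phenyl ring to another without leaving the scatter. Compound 1 carries the same 2-fluorophenyl group as compound 4 but on a core without the two methoxy groups; in this assay compound 1 gives 4610 nM, which sits within the scatter of the value of compound 3. Among the measured compounds shown here, no single-change step links compound 1 to the others.

For the measured compounds named here, with the only comparable step being within the scatter, compound 4 is expected to show a 1.1-fold lower number from compound 3 to compound 4 (0.03 log units; within the scatter), no step beyond the scatter. The estimate for compound 4 in this assay is 7000 nM, between 3500 nM and 14000 nM.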

Compound 4, half-maximal inhibitory concentration: 12700 nM
Compound 4: middle estimate off by 1.8-fold (0.26 log units), on the low side, and the stated range covers the measured number.
By their numbers in this assay, from the lowest: compounds 1, 3, 2 and 4 (each within the scatter of the next, the first and the last beyond it).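

In this assay, within the data shown here, the step of a 1.3-fold higher number from compound 2 to compound 4 (0.12 log units; within the scatter) is the first to read the halogen itself, with fluoro in place of chloro on an aromatic carbon, and the earlier step had only moved the chlorine. The wider change, 2-fluorophenyl in place of 4-chlorophenyl on a carbonyl carbon, gives a 1.7-fold higher number from compound 3 to compound 4 (0.23 log units; within the scatter), so changing the halogen and the group's substitution pattern together also stays inside the scatter. On the shared core, this assay therefore does not separate the 2-chlorophenyl, 4-chlorophenyl and 2-fluorophenyl groups on the carbonyl carbon, and no order among compound 2, compound 3 and compound 4 can be drawn from these numbers.

Nothing available here offers an explanation for these numbers. The compounds shown leave open whether a different kind of group on this phenyl ring, such as an amine or a carboxylic acid, or a longer chain in place of the ring on the carbonyl carbon, would give a step beyond the scatter.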